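The source may hold more compounds than are shown below. What is called first, only, known or untested is meant among the compounds shown, and "the series" means these compounds.

Three compounds were measured for growth inhibition of a glioblastoma-derived cell line:

Compound 1, `ClCc1cccc(Cn2cnc3c(Cl)ncnc32)c1`: 3230 nM
Compound 2, `ClCc1ccc(Cn2cnc3nc(Cl)nc(Cl)c32)cc1`: 1810 nM
Compound 3, `ClCc1cccc(Cn2cnc3c(Cl)nc(Cl)nc32)c1`: 4360 nM

In a functional assay on SF-295 cells (Homo sapiens) for cytotoxicity, read by sulforhodamine B assay, with a stated time of 48 h (a higher number here means a weaker inhibitor of growth, a lower number a stronger inhibitor of growth), compound 2 gives 1810 nM, the lowest number of the three; its nearest neighbour is compound 1 with 3230 nM, a gap that stays within the scatter, while compound 3 with 4360 nM lies beyond it. Compound 1 and compound 3 share a core and differ in one place: hydrogen in place of chloro on an aromatic carbon. This change produced a 1.3-fold lower number from compound 3 to compound 1 (0.13 log units; within the scatter), so nothing can be claimed for it from this pair alone. Compound 2 and compound 3 are built from the same atoms joined differently, and the difference between the two cores is not broken down here.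

Compound 4, `ClCc1ccc(Cn2cnc3ncnc(Cl)c32)cc1`, has not yet been measured in this assay. It relates to compound 2 exactly as compound 1 relates to compound 3: hydrogen in place of chloro on an aromatic carbon. The two descriptions of the place of change agree word for word, so it is the same change made on a second core. Within the data shown here, the only guide is the earlier pair, which moved by a 1.3-fold lower number from compound 3 to compound 1 (0.13 log units; within the scatter); on that basis a step of a 1.3-fold lower number from compound 2 to compound 4 (0.11 log units; within the scatter) is expected, small enough to fall within the scatter. Compound 4 is therefore estimated to give about 1400 nM in this assay, with a plausible range from 700 nM to 2800 nM.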

Compound 4, concentration for 50% growth inhibition: 2040 nM
Compound 4: middle estimate off by 1.5-fold (0.16 log units), on the low side; the measured number falls inside the stated range.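

In this assay, putting hydrogen in place of the chloro group between two ring nitrogen atoms gave a 1.1-fold higher number from compound 2 to compound 4 (0.05 log units; within the scatter), so on the core of compound 2 this change leaves no readable mark on growth inhibition. Set beside the earlier pair, the step does not differ from the one seen on the other core, and so far the change carries from one core to the other as a step too small to read: the same change on two cores in this assay, a 1.3-fold lower number (0.13 log units; within the scatter) from compound 3 to compound 1 and a 1.1-fold higher number (0.05 log units; within the scatter) from compound 2 to compound 4, 1.5-fold (0.18 log units) apart, within the scatter of two such steps

Among these compounds, both steps lie within the scatter, so the two pairs show only that this chloro group can give way to hydrogen on these two cores without a readable change in this cell line; they do not establish a direction for the change, and they do not show that it would behave the same way on a third core or in other cells.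

The compounds shown leave open whether a group other than chloro or hydrogen at this place, such as an amine or a methoxy group, would move the number at all. Every compound shown also carries a chloromethyl group, and what happens when a hydroxymethyl or a plain methyl group stands in its place remains open.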